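The source may report more compounds than this note shows. Statements on the series, on what has been measured and on what is new or still open speak of the compounds shown alone.

Measured in a functional assay on cells (Cancer cell lines, Homo sapiens) for cytotoxicity, read by sulforhodamine B assay, with a stated time of 48 h; a lower number here means a stronger inhibitor of growth, a higher number a weaker inhibitor of growth:
Compound 1 `O=C1N=C(N2N=C(c3ccccc3)CC2c2ccc(Cl)cc2)S/C1=C1/C(=O)Nc2ccccc21`: 190 nM
Compound 2 `CN(C)c1ccc(C2CC(c3ccccc3)=NN2C2=NC(=O)/C(=C3\C(=O)Nc4ccccc43)S2)cc1`: 1110 nM

Within the data shown here, compound 2 stands at the higher of the two numbers in this assay; the only measured step is a 5.8-fold higher number from compound 1 to compound 2 (0.77 log units; beyond the scatter), which concerns a different ring. Compound 3 `CN(C)c1ccc(C2CC(c3ccccc3)=NN2C2=NC(=O)/C(=C3\C(=O)Nc4ccc(Cl)cc43)S2)cc1` differs from compound 2 by chloro in place of hydrogen on an aromatic carbon. Among the measured compounds shown here, no measured step touches this position, so that step gives no direct guide. Compound 3 is therefore expected to stay close to its parent, with a step of a 1.1-fold lower number from compound 2 to compound 3 (0.05 log units; within the scatter) in this assay within the usual scatter. The estimate for compound 3 is 1000 nM, within a range of 400 nM to 2500 nM.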

Compound 3, concentration for 50% growth inhibition: 190 nM
The estimate for compound 3 lay 5.3-fold (0.72 log units) above the measured number, outside the stated range (below it).
By their numbers in this assay, from the lowest: compounds 1 and 3 (each within the scatter of the next); then compound 2.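

Chloro in place of hydrogen on an aromatic carbon of the six-membered aromatic ring, part of a fused or bridged system of two rings, gives a 5.8-fold lower number from compound 2 to compound 3 (0.77 log units; beyond the scatter) in this assay. Among these compounds, the only earlier step concerned a different ring, so this is the first sign that this position responds to a change, and the step lies beyond the scatter. Nothing available accounts for the size of this step. The compounds shown leave open whether fluoro, methoxy or nitro at this position would give a similar step.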